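A few compounds are considered here, and "the series" means these few. Any claim that something is new, unique, unknown or untested is made for them only; others in the source may bear on it.

Measured so far in an in vitro ADME assay on microsomes from liver (Homo sapiens) for metabolic stability, with a stated time of 60 min, tested at 1 uM; a lower number here means slower removal, a higher number faster removal of the compound:
Compound 1 `Cc1ccc(-c2cc(-c3ccc(S(C)(=O)=O)cc3)cnc2N)cn1`: < 5 mL.min-1.g-1 (a limit)
Compound 2 `CS(=O)(=O)c1ccc(-c2cnc(N)c(-c3ccc(C(F)(F)F)c(F)c3)c2)cc1`: 14 mL.min-1.g-1

Compound 1 has no exact number on this read-out: its result of < 5 mL.min-1.g-1 is a limit of the assay, not a measured value. This is the limit of < 5 mL.min-1.g-1 in this assay, at which 1 of the 2 values shown sits. Compound 2, by contrast, has a true number, 14 mL.min-1.g-1.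

The compound still to be tested, compound 3 `CS(=O)(=O)c1ccc(-c2cnc(N)c(-c3ccc(C#N)cc3)c2)cc1`, keeps the core of compound 1 and changes one group: 4-cyanophenyl in place of 6-methylpyridin-3-yl on an aromatic carbon, ortho to an amino group (4-cyanophenyl in place of 6-methylpyridin-3-yl on an aromatic carbon). Within the data shown here, no measured pair of compounds differing in one place shows what such a swap does, so any expectation here is loose. Among the measured compounds shown here, with compound 2 at 14 mL.min-1.g-1 as the only true number available, a small rise in this assay is expected rather than a large one. The expected change is modest, an at least 1.4-fold higher number from compound 1 to compound 3 (0.14 log units; that floor lies within the scatter), and the assay may again report only a limit. Compound 3 is estimated at 7 mL.min-1.g-1, with an expected range of 4 mL.min-1.g-1 to 16 mL.min-1.g-1.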

Compound 3, intrinsic clearance in microsomes: < 5 mL.min-1.g-1
Compound 3: no number, only a limit (the forecaster's own chance of this, stated with the estimate: 35%); middle value at least 1.4-fold (0.14 log units) away from the limit.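

Compound 3 gives < 5 mL.min-1.g-1, a limit of the assay and not a number. Compound 1 and compound 3 both rest on that limit, so no step can be read between them: the limit of < 5 mL.min-1.g-1 in this assay, at which 2 of the 3 values shown sit. The compounds shown leave open how the two truly compare in this assay, and so what 4-cyanophenyl in place of 6-methylpyridin-3-yl does to the read-out.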